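Series notes: shortened aminocyclohexyl arm on the amine nitrogen

The compounds below may be only part of what the source reports. "The series", "measured", "known", "first", "only" and "open" are said of these compounds alone.

Three analogues of the shared core have been run in a functional assay on CCRF-CEM cells for antagonist activity at C-X-C chemokine receptor type 4 (Homo sapiens), read by calcium flux, with stated times of 25 min and 90 s; on this read-out lower numbers stand for stronger inhibition and higher numbers for weaker inhibition. Compound 1 `N[C@H]1CC[C@H](CN(C[C@H]2Cc3ccccc3CN2)[C@H]2CCCc3cccnc32)CC1` gives 280 nM, compound 2 `C/C(CN(C[C@H]1Cc2ccccc2CN1)[C@H]1CCCc2cccnc21)=C(\F)CN` gives 80 nM, and compound 3 `NCC1=C(CN(C[C@H]2Cc3ccccc3CN2)[C@H]2CCCc3cccnc32)CCCC1` gives 230 nM. Compound 3 thus stands second highest of the three numbers: against compound 1 the step is a 1.2-fold lower number from compound 1 to compound 3 (0.09 log units; within the scatter), against compound 2 it is a 2.9-fold higher number from compound 2 to compound 3 (0.46 log units; beyond the scatter), and compound 2 also separates from compound 1 by a 3.5-fold lower number from compound 1 to compound 2 (0.54 log units; beyond the scatter).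

Compound 4 `N[C@H]1CC[C@@H](N(C[C@H]2Cc3ccccc3CN2)[C@H]2CCCc3cccnc32)CC1` is the next to be measured. The change from compound 3 is 4-aminocyclohexyl in place of (2-(aminomethyl)cyclohex-1-en-1-yl)methyl on an amine nitrogen, the group entering being one with a six-membered ring and two defined stereocentres, and the linking chain carbon of compound 3 is gone. Only the ring-for-ring swap has a precedent, and that step was within the scatter. Nothing measured covers the loss of the chain carbon, so the expected step of a 1.3-fold higher number from compound 3 to compound 4 (0.12 log units; within the scatter) is taken as small, with a wide band. In this assay compound 4 is estimated at 300 nM, within 100 nM to 900 nM.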

Compound 4, half-maximal inhibitory concentration: 1800 nM
Beside the measured number, compound 4's estimate is 6.0-fold (0.78 log units) below it; measured number outside the range, above it.
By their numbers in this assay, from the lowest: compound 2; then compounds 3 and 1 (each within the scatter of the next); then compound 4.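

In this assay the step with 4-aminocyclohexyl in place of (4-aminocyclohexyl)methyl is a 6.4-fold higher number from compound 1 to compound 4 (0.81 log units; beyond the scatter). Among these compounds, it is the one step here that changes only the saturated chain carbon on the amine nitrogen, which all three earlier compounds carry. The other two arms give the same direction, with a 7.8-fold higher number from compound 3 to compound 4 (0.89 log units; beyond the scatter) and with a 23-fold higher number from compound 2 to compound 4 (1.35 log units; beyond the scatter) as the largest step in the series, so compound 4 is the weakest of the four, beyond the scatter of each. The data on hand offer no explanation for this loss.

Still open, as far as these compounds go, is whether a longer chain to the 4-aminocyclohexyl ring would improve on the single chain carbon or lose inhibition again. A 4-aminobutyl arm or a piperidine ring on the amine nitrogen would also test whether the ring itself matters.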